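This account rests on a few compounds, and the source may have more. Where it says the series, first, only, none or still open, it means among the compounds named here.

Measured so far:
- compound 1, `O=C(NO)[C@H]1CCCC1S(=O)(=O)c1ccc(C#Cc2ccccc2)cc1` — 0.91 nM in an assay on isolated protein for inhibition of matrix metalloproteinase-9 (Homo sapiens), read by fluorescence, with stated times of 5 min and 30 min; on this read-out higher numbers stand for weaker inhibition and lower numbers for stronger inhibition
- compound 2, `O=C(NO)[C@H]1CCCC1S(=O)(=O)c1ccc(-c2ccc(Cl)c(Cl)c2)cc1` — 0.76 nM in this assay

Compound 2 holds the lowest of the two numbers, and its nearest neighbour is compound 1; the gap between them is a 1.2-fold lower number from compound 1 to compound 2 (0.08 log units; within the scatter), so the two stand level. That step swapped one large group for another on the same aromatic carbon and moved the number hardly at all.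

Compound 3, `O=C(Nc1ccc(S(=O)(=O)C2CCC[C@@H]2C(=O)NO)cc1)c1ccccc1`, has not been measured. It differs from compound 2 in one place: benzamido in place of 3,4-dichlorophenyl on an aromatic carbon. Among the measured compounds shown here, the only measured step that bears on this is the one from compound 1 to compound 2, which also replaced the large group on that aromatic carbon and stayed within the scatter. For the measured compounds named here, since the incoming benzamido brings a hydrogen-bond donor and acceptor that neither earlier group carried, there is no direct precedent for it, so the expectation is more uncertain. Compound 3 is expected to give a somewhat higher number, with an estimated step of a 3.9-fold higher number from compound 2 to compound 3 (0.60 log units; beyond the scatter). For compound 3 the estimate in this assay is 3 nM, with a range from 0.5 nM to 20 nM.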

Compound 3, half-maximal inhibitory concentration: 47 nM
Estimate against measurement, compound 3: 16-fold (1.19 log units) below; the whole stated range lies below it.
By their numbers in this assay, from the lowest: compounds 2 and 1 (each within the scatter of the next); then compound 3.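

Compound 1 and compound 2 alone could suggest that this aromatic carbon, para to a large group, accepts quite different large groups without consequence, but benzamido shows otherwise in this assay (a 62-fold higher number from compound 2 to compound 3 (1.79 log units; beyond the scatter); a 52-fold higher number from compound 1 to compound 3 (1.71 log units; beyond the scatter)). Both steps are large and point the same way, so inhibition here depends on which group is attached, not merely on a large group being present. Benzamido and 3,4-dichlorophenyl are close in heavy-atom count and each carries one six-membered aromatic ring, so those shared features do not keep the number low; benzamido also adds a hydrogen-bond donor, a hydrogen-bond acceptor and a carbonyl double bond, but no measurement here accounts for the loss.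

The compounds shown leave open which part of the benzamido group goes with the higher number, the amide hydrogen, the carbonyl or the way the amide links the two rings. An N-methylbenzamido group or a benzylamino group, each changing one of those parts, could begin to separate them.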